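Butyl to phenyl on the amine nitrogen: lipophilicity notes

This account rests on a few compounds, and the source may have more. Where it says the series, first, only, none or still open, it means among the compounds named here.

Measured in a physicochemical assay for lipophilicity, at pH 7.4; on this read-out higher numbers stand for higher lipophilicity and lower numbers for lower lipophilicity:
compound 1 `CCCCNc1nc(NCc2ccccc2)c2ccccc2n1` gives 3.8
compound 2 `c1ccc(CNc2nc(Nc3ccccc3)nc3ccccc23)cc1` gives 4.17
compound 3 `CCCCNc1nc(NCc2ccccc2)nc2ccccc12` gives 3.84

Compound 2 differs from compound 1 by phenyl in place of butyl on a nitrogen on an aromatic ring, and this gave a number 0.37 log units higher from compound 1 to compound 2 (beyond the scatter). Compound 3 has the same atoms as compound 1 joined differently; the difference between the two cores is not broken down here, and the values of compound 3 and compound 1 lie within the scatter of each other, while compound 2 stands beyond the scatter from both.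

Compound 4 `c1ccc(CNc2nc(Nc3ccccc3)c3ccccc3n2)cc1` is not yet measured. It differs from compound 3 by phenyl in place of butyl on a nitrogen on an aromatic ring, the same change at the same place as from compound 1 to compound 2. The step is expected to be a number 0.37 log units higher from compound 3 to compound 4 (beyond the scatter), close to the earlier one. Within the data shown here, that expectation rests on a number 0.37 log units higher from compound 1 to compound 2 (beyond the scatter) as the single measured instance of this change. For compound 4 the estimate is 4.21, with a range from 3.9 to 4.52.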

Compound 4, distribution coefficient: 4.25
Estimate against measurement, compound 4: 0.04 log units below; the range from low to high includes it.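

In this assay, phenyl in place of butyl on a nitrogen on an aromatic ring gave a number 0.41 log units higher from compound 3 to compound 4 (beyond the scatter), in the same direction as a number 0.37 log units higher from compound 1 to compound 2 (beyond the scatter), so the change carried over between these two cores. This rests on one pair on each core and does not show that the step would hold on any further core or for any other group on this nitrogen. Nothing available accounts for the size of the step or for its recurrence.

The compounds shown leave open what a longer chain, a cyclohexyl group or a phenyl bearing a carboxylic acid would do on this nitrogen. On these data alone, whether such groups would give matching steps on both cores also remains open.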